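A few compounds are considered here, and "the series" means these few. Any claim that something is new, unique, unknown or untested is made for them only; others in the source may bear on it.

Compound 1 `COc1ccc(C(=O)/C=C/c2ccc(F)cc2)c2c1C=CC(C)(C)O2` gives > 10000 nM.
Compound 2 `COc1ccc(C(=O)/C=C/c2ccc(N(c3ccccc3)c3ccccc3)cc2)c2c1C=CC(C)(C)O2` gives > 10000 nM.

In a functional assay on SW-620 cells (Homo sapiens) for antiproliferative activity, read by MTT assay, with a stated time of 24 h (a lower number here means a stronger inhibitor, a higher number a weaker inhibitor), compound 1 reaches only a limit, > 10000 nM. Compound 2 likewise ends at a limit, > 10000 nM. Among the measured compounds shown here, both measured entries sit at the limit of > 10000 nM in this assay, at which 2 of the 2 values shown sit, so compound 1 stands level with the one other entry and no ranking within the pair follows. Compound 3 `COc1ccc(C(=O)/C=C/c2ccc(-n3ccnc3)cc2)c2c1C=CC(C)(C)O2` carries 1H-imidazol-1-yl in place of fluoro on an aromatic carbon. For the measured compounds named here, no measured step of this kind exists. The expected step from compound 1 to compound 3 is estimated as an at least 1.2-fold lower number from compound 1 to compound 3 (0.09 log units; that floor lies within the scatter), a shift not clearly beyond the scatter. Compound 3 is estimated at 8000 nM, with a range from 2000 nM to 30000 nM.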

Compound 3, half-maximal inhibitory concentration: > 10000 nM
Compound 3: only a limit was reported (the forecaster's own chance of this, stated with the estimate: 60%); at least 1.2-fold (0.09 log units) between middle value and limit.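

In this assay, no step from compound 1 to compound 3 can be read, because both compounds end at a limit: the limit of > 10000 nM in this assay, at which 3 of the 3 values shown sit.

The compounds shown leave open whether 1H-imidazol-1-yl in place of fluoro shifts the read-out at all, and how compound 1, compound 2 and compound 3 rank.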